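This account rests on a few compounds, and the source may have more. Where it says the series, first, only, none or still open, it means among the compounds named here.

Measured in a functional assay on HepG2 cells (Homo sapiens) for cytotoxicity, read by MTT assay, with a stated time of 48 h (a higher number here means a weaker inhibitor, a lower number a stronger inhibitor), so far
compound 1 `O=C1/C(=C\c2ccc(O)cc2)S/C(=N/c2ccccc2)N1Cc1ccncc1` gives 11800 nM
compound 2 `O=C1/C(=C\c2ccc(Cl)cc2)S/C(=N/c2ccccc2)N1Cc1ccncc1` gives 28800 nM
compound 3 `COc1ccc(/C=C2/S/C(=N/c3ccccc3)N(Cc3ccncc3)C2=O)cc1OC` gives 28900 nM

Compound 3 stands at the high end of this small set, level with the other high value, as a 1.0-fold higher number from compound 2 to compound 3 (0.00 log units; within the scatter) shows in the comparison.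

Compound 4 `COc1cc(/C=C2/S/C(=N/c3ccccc3)N(Cc3ccncc3)C2=O)ccc1O` has hydrogen in place of methyl on an oxygen on an aromatic ring, which reads as 3,4-dimethoxyphenyl to 4-hydroxy-3-methoxyphenyl.

Within the data shown here, no measured step isolates this change. The closest evidence is a 2.4-fold higher number from compound 1 to compound 3 (0.39 log units; beyond the scatter) for 3,4-dimethoxyphenyl in place of 4-hydroxyphenyl. Beside it stands a 2.4-fold higher number from compound 1 to compound 2 (0.39 log units; beyond the scatter) for chloro in place of hydroxy. Among the measured compounds shown here, both steps are modest, and both start from the one compound with a hydroxy group. Compound 4 regains that hydroxy but keeps a methoxy, so part of the first step is expected to reverse, giving a lower number by a modest margin near the edge of the scatter.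

The expected step is a 1.8-fold lower number from compound 3 to compound 4 (0.26 log units; within the scatter) in this assay for now.

For compound 4 the estimate is 16000 nM with an expected range from 8000 nM to 30000 nM as the working figure.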

Compound 4, half-maximal inhibitory concentration: 28600 nM
Estimate against measurement, compound 4: 1.8-fold (0.25 log units) below; low and high end bracket the measured number.
By their numbers in this assay, from the lowest: compound 1; then compounds 4, 2 and 3 (each within the scatter of the next).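

In this assay, the step from methoxy to hydroxy on the 3,4-dimethoxyphenyl group reads as a 1.0-fold lower number from compound 3 to compound 4 (0.00 log units; within the scatter) and leaves the two compounds level. Set against the 4-chlorophenyl group, the 4-hydroxy-3-methoxyphenyl group gives a 1.0-fold lower number from compound 2 to compound 4 (0.00 log units; within the scatter) and is level as well, so a hydroxy on this aromatic ring does not by itself bring the number down to that of compound 1. Only the remaining step lies beyond the scatter, a 2.4-fold higher number from compound 1 to compound 4 (0.38 log units; beyond the scatter) for methoxy in place of hydrogen on an aromatic carbon, so within these compounds the lower number goes with the 4-hydroxyphenyl group without the added methoxy.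

As far as these compounds go, whether an amine or a carboxylic acid in place of that methoxy would give a number like that of compound 1 or stay level with the other three remains open. No evidence at hand gives a cause for any of these steps.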